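This account rests on a few compounds, and the source may have more. Where it says the series, first, only, none or still open, it means among the compounds named here.

Compound 1, `O=C1Nc2ccc(Br)cc2/C1=C/c1cccc(OCc2cn(Cc3ccccc3)nn2)c1`: > 50000 nM
Compound 2, `COc1ccc(Cc2ccc3c(c2)/C(=C\c2cccc(OCc4cn(Cc5ccccc5)nn4)c2)C(=O)N3)cc1`: > 50000 nM

Of the compounds shown here, two have so far been tested in a functional assay on BT-549 cells (Homo sapiens) for inhibition, read by MTT assay, with a stated time of 48 h; a higher number here means a weaker inhibitor, a lower number a stronger inhibitor. Compound 1 gives > 50000 nM, which is a limit of the assay rather than a measured number. Compound 2 likewise gives > 50000 nM, again a limit and not a number. Going by the values given here, compound 2 therefore stands at the edge of what this assay can report, and that is where every value so far sits: the limit of > 50000 nM in this assay, at which 2 of the 2 values shown sit. Among the compounds with values here, no two measured compounds differ in only one place, so no step size has yet been observed.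

Compound 3, `COc1ccc(Cc2ccc3c(c2)/C(=C/c2cccc(OCc4cn(Cc5ccccc5)nn4)c2)C(=O)N3)cc1`, is the next compound to be measured. Compared with compound 2, (the two compounds have the same atoms and bonds and differ only in configuration as drawn: 1 of 1 stereo elements differ; a double bond is drawn E in compound 2 and Z in compound 3). Within the data shown here, with no measured step to lean on, the expected step is a number no higher from compound 2 to compound 3 (the limit leaves the size open), meaning no change beyond the usual scatter. Compound 3 is most likely to return only a limit again, and its value is estimated at 50000 nM, within a range from 15000 nM to 200000 nM.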

Compound 3, half-maximal inhibitory concentration: 36000 nM
Compound 3: middle estimate off by 1.4-fold (0.14 log units), on the high side; low and high end bracket the measured number.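

Going by these compounds alone, compound 3 is the first compound in this assay to give a real number rather than a limit, and its structure changes only in how the double bond is drawn: the fact that compounds 2 and 3 differ only in the configuration as drawn. Turning that double bond from E to Z gives an at least 1.3-fold lower number from compound 2 to compound 3 (0.14 log units; that floor lies within the scatter), but this is only a floor, so the data cannot yet say whether configuration matters here. Placing 4-methoxybenzyl in place of bromo on an aromatic carbon gives an at least 1.3-fold lower number from compound 1 to compound 3 (0.14 log units; that floor lies within the scatter), again a floor that shows no change beyond the scatter.

On these data alone, the true size of both steps stays open, as the other two values are limits rather than numbers: the limit of > 50000 nM in this assay, at which 2 of the 3 values shown sit. Also open, as far as these compounds go, is whether an amine or a carboxylic acid at the place of the 4-methoxybenzyl group would give a clearly lower number.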